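The source may report more compounds than this note shows. Statements on the series, on what has been measured and on what is new or still open speak of the compounds shown alone.

Measured compounds:
- compound 1, `COC(=O)/C(=C\c1ccc(OC(=O)c2ccc(OC)cc2)cc1)Sc1ccnc2cc(Cl)ccc12`: 9090 nM
- compound 2, `COC(=O)/C(=C\c1ccc(OC(=O)c2ccccc2OC)cc1)Sc1ccnc2cc(Cl)ccc12`: 44500 nM
- compound 3, `COC(=O)/C(=C\c1ccc(OC(=O)c2c(OC)cccc2OC)cc1)Sc1ccnc2cc(Cl)ccc12`: 37200 nM

All three share one core and differ only in the methoxy-bearing phenyl attached to the carbonyl carbon of the ester. In a functional assay on HL-60 cells (Homo sapiens) for cytotoxicity, read by MTT assay, with a stated time of 24 h (a higher number here means a weaker inhibitor, a lower number a stronger inhibitor), compound 3 stands second highest of the three numbers; its nearest neighbour is compound 2, and the gap between them, a 1.2-fold lower number from compound 2 to compound 3 (0.08 log units; within the scatter), is within the scatter. Its furthest neighbour is compound 1, and the gap a 4.1-fold higher number from compound 1 to compound 3 (0.61 log units; beyond the scatter) is beyond the scatter, as is the related step of a 4.9-fold higher number from compound 1 to compound 2 (0.69 log units; beyond the scatter).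

Compound 4, `COC(=O)/C(=C\c1ccc(OC(=O)c2cc(OC)cc(OC)c2OC)cc1)Sc1ccnc2cc(Cl)ccc12`, has not yet been measured in this assay. It differs from compound 3 in one place: 2,3,5-trimethoxyphenyl in place of 2,6-dimethoxyphenyl on a carbonyl carbon. The steps seen so far suggest that moving or adding methoxy groups on this phenyl ring changes the number by a modest amount at most, since a 1.2-fold lower number from compound 2 to compound 3 (0.08 log units; within the scatter) lay within the scatter, while only the change away from 4-methoxyphenyl gave a step beyond the scatter. Compound 4 keeps a methoxy group in the 2-position and adds others, so the expected step of a 1.1-fold lower number from compound 3 to compound 4 (0.03 log units; within the scatter) is small, with no clear direction beyond the scatter. The estimate for compound 4 in this assay is therefore 35000 nM, with a range from 14000 nM to 90000 nM.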

Compound 4, half-maximal inhibitory concentration: 10700 nM
Estimate against measurement, compound 4: 3.3-fold (0.51 log units) above; the whole stated range lies above it.
By their numbers in this assay, from the lowest: compounds 1 and 4 (each within the scatter of the next); then compounds 3 and 2 (each within the scatter of the next).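

In this assay, for the compounds shown here, the choice of methoxy pattern on the phenyl attached to the carbonyl carbon matters more than the earlier compounds suggested: the step of a 3.5-fold lower number from compound 3 to compound 4 (0.54 log units; beyond the scatter) and the step of a 4.2-fold lower number from compound 2 to compound 4 (0.62 log units; beyond the scatter) both lie beyond the scatter, so keeping a 2-substituted name on the ring does not by itself fix the number. The earlier compounds shown here left 4-methoxyphenyl alone at the low end, but the step of a 1.2-fold higher number from compound 1 to compound 4 (0.07 log units; within the scatter) lies within the scatter, so 2,3,5-trimethoxyphenyl and 4-methoxyphenyl cannot be told apart here, and compound 2 and compound 3 remain the two with the higher numbers. No measurement in hand explains why 2,3,5-trimethoxyphenyl differs from 2,6-dimethoxyphenyl in this way.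

Which of the methoxy groups in 2,3,5-trimethoxyphenyl accounts for the change stays open, since this group differs from the others by more than one methoxy group. Also open, going by these compounds, is whether this phenyl would give a similar number when it carries something other than methoxy, such as an amine or a carboxylic acid.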